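Swapping a Benzyl for a Phenylthiourea on a Weak Scaffold

The compounds below may be only part of what the source reports. "The series", "measured", "known", "first", "only" and "open" are said of these compounds alone.

Compound 1, `NC(=O)c1c(NC(=O)c2ccccc2Cl)sc2c1CCN(Cc1ccccc1)C2`, is the starting point. In a functional assay on HeLa cells (Homo sapiens) for antiproliferative activity, with a stated time of 24 h (on this read-out lower numbers stand for stronger inhibition and higher numbers for weaker inhibition), compound 1 gives 38400 nM, a weak result. A second compound, compound 2, `NC(=O)c1c(NC(=O)c2ccc(C(F)(F)F)cc2)sc2c1CCN(Cc1ccc(Cl)cc1)C2`, carries a trifluoromethyl-substituted benzoyl amide and a chlorobenzyl group on the ring nitrogen. In this assay compound 2 gives only a limit of the assay, > 50000 nM. Compound 1 thus holds the only true number shown, while the other value sits at the limit of > 50000 nM in this assay, at which 1 of the 2 values shown sits. Compound 3, `NC(=O)c1c(NC(=O)c2ccccc2Cl)sc2c1CCN(C(=S)Nc1ccccc1)C2`, keeps the shared core and the chlorobenzoyl amide of compound 1 but changes the group on the amine nitrogen in the ring: a group of 9 heavy atoms (7 carbon, 1 nitrogen, 1 sulfur; one six-membered aromatic ring of carbon only) in place of a group of 7 heavy atoms (7 carbon; one six-membered aromatic ring of carbon only), on an amine nitrogen in a ring. For the measured compounds named here, no measured pair differs in only this place, so the size of the step is uncertain. Compound 3 is expected to give 30000 nM in this assay, with a plausible range from 8000 nM to 100000 nM. This estimate means an expected step of a 1.3-fold lower number from compound 1 to compound 3 (0.11 log units; within the scatter), which stays within the usual scatter.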

Compound 3, half-maximal inhibitory concentration: 46700 nM
For compound 3 the middle estimate is 1.6-fold (0.19 log units) below the measured one; the measured number falls inside the stated range.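

For the compounds shown here, this pair gives the first direct reading at this position: replacing benzyl with the phenylthiourea group on the amine nitrogen in the ring gives a 1.2-fold higher number from compound 1 to compound 3 (0.08 log units; within the scatter). Going by these compounds alone, the larger group, with its added hydrogen-bond donor and acceptor, therefore leaves the result in this assay unchanged within the usual scatter, and the single pair shows neither a gain nor a loss from this swap. Compound 2 is the one compound here whose result is a limit of the assay: the limit of > 50000 nM in this assay, at which 1 of the 3 values shown sits.

As far as these compounds go, it remains open whether any group on this nitrogen can produce a real gain, such as an acetyl group, a carboxylic acid or a short chain ending in an amine. Also open, from the compounds shown here alone, is whether the phenylthiourea group would behave the same way alongside a different benzoyl amide.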